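Hydroxy to Amino on a Saturated Chain Carbon

The compounds below may be only part of what the source reports. "The series", "measured", "known", "first", "only" and "open" are said of these compounds alone.

Among the measured compounds shown here, in a functional assay (trachea) with Cavia porcellus as the target (on this read-out higher numbers stand for weaker inhibition and lower numbers for stronger inhibition), compound 1 `O=c1c2ccccc2c(-c2cccnc2)nn1CCSc1ccccc1` reads 9120 nM and compound 2 `O=c1c2ccccc2c(-c2cccnc2)nn1CCO` reads 4570 nM (the only two numbers so far). These two values lie within the scatter of each other, so compound 2 stands level with compound 1 on this evidence. Compound 3 `NCCn1nc(-c2cccnc2)c2ccccc2c1=O` carries amino in place of hydroxy on a saturated chain carbon, two bonds along the chain from an aromatic nitrogen. For the measured compounds named here, one measured step touches this carbon, the exchange of phenylsulfanyl for hydroxy, and it gave a 2.0-fold lower number from compound 1 to compound 2 (0.30 log units; within the scatter) in the same read-out. Going by the values given here, no measured step exchanges hydroxy for amino, so the evidence is indirect. In this assay no change beyond the scatter is therefore expected, and the estimated step is a 1.1-fold lower number from compound 2 to compound 3 (0.06 log units; within the scatter) without a firm direction. For compound 3 the estimate is 4000 nM (range 1300 nM to 13000 nM).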

Compound 3, half-maximal inhibitory concentration: > 100000 nM
Compound 3 gave a limit, no number; the forecaster's own chance of this, stated with the estimate: 10%; middle value at least 25-fold (1.39 log units) away from the limit.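

In this assay, amino in place of hydroxy on this saturated chain carbon, two bonds along the chain from an aromatic nitrogen, gives an at least 21-fold higher number from compound 2 to compound 3 (1.34 log units; beyond the scatter), and amino in place of phenylsulfanyl gives an at least 10-fold higher number from compound 1 to compound 3 (1.04 log units; beyond the scatter). Hydroxy and phenylsulfanyl read level with each other at this position, whereas amino stands apart from both, even though hydroxy and amino match in heavy atoms, hydrogen-bond donors and hydrogen-bond acceptors. The value of compound 3 is a limit of the assay and not a number: the limit of > 100000 nM in this assay, at which 1 of the 3 values shown sits.

The compounds shown leave open whether a methylamino or dimethylamino group at this position would read like the amino group of compound 3. They also leave open how a longer chain, such as 3-aminopropyl, or a carboxylic acid on this chain would read.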